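The source may hold more compounds than are shown below. What is called first, only, known or untested is meant among the compounds shown, and "the series" means these compounds.

Measured so far:
- compound 1, `N#CSc1c(-c2ccccc2)nc2sc(Cc3ccccc3)nn12`: 15500 nM
- compound 2, `O=Cc1c(-c2ccc([N+](=O)[O-])cc2)nc2sc(Cc3ccccc3)nn12`: 3000 nM

In a functional assay on cells (Cancer cell lines, Homo sapiens) for inhibition (a lower number here means a stronger inhibitor of growth, a higher number a weaker inhibitor of growth), compound 2 gives 3000 nM, the lower of the two numbers; compound 1 gives 15500 nM in this assay, a gap that lies beyond the usual scatter. Among the measured compounds shown here, no pair of measured compounds differing in a single place exists here, so no measured step guides the next change.

Compound 3, `O=[N+]([O-])c1ccc(-c2nc3sc(Cc4ccccc4)nn3c2Br)cc1`, carries bromo in place of formyl on an aromatic carbon. The formyl leaves and bromo enters at the same aromatic carbon of the shared core; nothing else moves. For the measured compounds named here, with no comparable single-place step among the measured compounds, the expected size of the step in this assay is small, likely within the scatter, with a slight lean toward a higher number. The estimate for compound 3 is 5000 nM, within 1500 nM to 15000 nM, meaning an expected step of a 1.7-fold higher number from compound 2 to compound 3 (0.22 log units; within the scatter).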

Compound 3, concentration for 50% growth inhibition: 42700 nM
Beside the measured number, compound 3's estimate is 8.5-fold (0.93 log units) below it, and the stated range ends below it.
By their numbers in this assay, from the lowest: compound 2; then compound 1; then compound 3.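

In this assay, among the compounds shown here, bromo in place of formyl on an aromatic carbon gives a 14-fold higher number from compound 2 to compound 3 (1.15 log units; beyond the scatter), the first single-place step. It shows that the group on this aromatic carbon, next to the ring nitrogen, matters to growth inhibition: with everything else in the shared core unchanged, formyl holds the lower number of this pair, and bromo does not serve as an equal replacement. No measurement at hand bears on what lies behind this step.

Still open, on these data alone, is whether another group on this carbon, such as an amine or a carboxylic acid, would give a lower number than formyl does. For the compounds shown here, also open is whether the same step would appear on a core without the nitro group, as no single-place pair tests this.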